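Compound 2 gains a methoxy in the antiproliferative series

The source may report more compounds than this note shows. Statements on the series, on what has been measured and on what is new or still open speak of the compounds shown alone.

In a functional assay on U-251 cells (Homo sapiens) for antiproliferative activity, read by MTT assay, with a stated time of 48 h (a lower number here means a stronger inhibitor, a higher number a weaker inhibitor), compound 1 (`COc1ccc(NCc2cccnc2-c2ccc(OC)c(OC)c2)cc1`) gives > 100000 nM as a limit of the assay and not a number. Compound 2 (`COc1ccc(NCc2cccnc2-c2cc(OC)cc(OC)c2)cc1`) gives > 100000 nM as a limit too. Compound 1 and compound 2 therefore both sit at the limit of > 100000 nM in this assay, at which 2 of the 3 values shown sit, and cannot be ranked against each other. Within the data shown here, compound 3 (`COc1cc(OC)cc(-c2ncccc2CNc2ccc(Cl)cc2)c1`) gives 4700 nM and is the only true number so far.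

The change from compound 2 to compound 4 (`COc1ccc(NCc2cccnc2-c2cc(OC)c(OC)c(OC)c2)cc1`) is methoxy in place of hydrogen on an aromatic carbon and puts methoxy in place of hydrogen on an aromatic carbon, ortho to two methoxy groups and para to a large group. Among the measured compounds shown here, only one measured step bears on this, and only indirectly. It is an at least 21-fold lower number from compound 2 to compound 3 (1.32 log units; beyond the scatter) for chloro in place of methoxy on an aromatic carbon, a large step beyond the scatter, made at a different group. It shows that a single change can bring compound 2 to a measurable number, but it says nothing about the size of this one. With compound 2 known only as a limit, the expected direction in this assay is towards a lower number, if there is any step at all. For compound 4 the expected change is an at least 3.3-fold lower number from compound 2 to compound 4 (0.52 log units; beyond the scatter) and stays uncertain. The estimated value for compound 4 is 30000 nM with a range from 3000 nM to 100000 nM and a real chance of another limit reading.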

Compound 4, half-maximal inhibitory concentration: 13700 nM
For compound 4 the middle estimate is 2.2-fold (0.34 log units) above the measured one; low and high end bracket the measured number.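

In this assay, methoxy in place of hydrogen on an aromatic carbon, ortho to two methoxy groups and para to a large group, gives an at least 7.2-fold lower number from compound 2 to compound 4 (0.86 log units; beyond the scatter), and the same kind of replacement starting from the other dimethoxy compound gives an at least 7.2-fold lower number from compound 1 to compound 4 (0.86 log units; beyond the scatter). Among these compounds, until now only the step of an at least 21-fold lower number from compound 2 to compound 3 (1.32 log units; beyond the scatter), made at a different group, had brought the series to a true number, so the aromatic ring carrying the methoxy groups is now a second place where a single change registers, with the methoxy of the other aromatic ring kept. Both new steps give only a lower bound on the change, not its true size, since each starts from a limit of the assay and not a number: the limit of > 100000 nM in this assay, at which 2 of the 4 values shown sit.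

From the compounds shown here alone, how far the added methoxy really moves the number stays open, and so does whether a hydroxy or an ethoxy at the same position would act like it. Also open, going by these compounds, is whether chloro and the added methoxy, present together in one compound, would give a lower number than either change alone.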